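Dropping the Drawn Configuration at the Chain Stereocentre

The source may hold more compounds than are shown below. What is called first, only, known or untested is meant among the compounds shown, and "the series" means these compounds.

Measured compounds:
Compound 1, `CC(C(=O)NCc1ccc(C(F)(F)F)nc1CCC(C)(C)C)c1ccc(NS(C)(=O)=O)c(F)c1`: 0.6 nM
Compound 2, `CCC1CCC(c2nc(C(F)(F)F)ccc2CNC(=O)[C@@H](C)c2ccc(NS(C)(=O)=O)c(F)c2)CC1`: 0.2 nM

Both compounds were tested in an assay on CHO cells for antagonist activity at transient receptor potential cation channel subfamily V member 1 (Homo sapiens), read by FLIPR and calcium flux; on this read-out lower numbers stand for stronger inhibition and higher numbers for weaker inhibition. Compound 2 gives 0.2 nM, the lowest of the two numbers; its nearest neighbour is compound 1 with 0.6 nM, a difference that lies beyond the usual scatter of this assay. Compound 3, `CCC1CCC(c2nc(C(F)(F)F)ccc2CNC(=O)C(C)c2ccc(NS(C)(=O)=O)c(F)c2)CC1`, is the next compound to be measured. It differs from compound 2 in one way: the two compounds have the same atoms and bonds; at least one stereo element is drawn with a configuration in one of them and without one in the other: 1 of 3 stereo elements differ; a stereocentre at a saturated chain carbon is drawn S in compound 2 and without a configuration in compound 3. Among the compounds with values here, no pair of already measured compounds shows this kind of step on its own, so nothing in the data tells how large it is here. A drawing with one configuration describes a single form, while a drawing without one leaves that open, so for compound 3 a small step toward a higher number in this assay is expected, possibly still within the scatter. The expected step is a 2.0-fold higher number from compound 2 to compound 3 (0.30 log units; within the scatter). For compound 3 the estimated value is 0.4 nM, with a range from 0.2 nM to 1 nM.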

Compound 3, inhibition constant: 0.3 nM
Estimate against measurement, compound 3: 1.3-fold (0.12 log units) above; the measured number falls inside the stated range.
By their numbers in this assay, from the lowest: compounds 2, 3 and 1 (each within the scatter of the next, the first and the last beyond it).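

In this assay the change at the chain stereocentre comes to a 1.5-fold higher number from compound 2 to compound 3 (0.18 log units; within the scatter) and so does not clearly separate the two compounds, whose only difference is one of drawing: (the fact that one of compounds 2 and 3 is drawn with a defined configuration and the other without, at the place where they differ). Compound 3 also makes a new comparison possible, since it differs from compound 1 in one place only. Putting 4-ethylcyclohexyl in place of 3,3-dimethylbutyl on an aromatic carbon comes to a 2.0-fold lower number from compound 1 to compound 3 (0.30 log units; within the scatter) and so this swap cannot be told apart from repeat-measurement noise either.

The compounds shown leave open how the opposite configuration at the stereocentre would read, and whether compound 3 holds one form or both. They also leave open how an amine such as morpholine, or a longer chain such as n-hexyl, would read in place of 4-ethylcyclohexyl.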